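Trimming the side chain of a chlorinated purine glycinamide

The source may hold more compounds than are shown below. What is called first, only, known or untested is meant among the compounds shown, and "the series" means these compounds.

Compound 1 `O=C(CN(c1nc(Cl)nc2[nH]cnc12)C1CC1)NCC(=O)OCc1ccccc1` and compound 2 `NC(=O)C[C@H](NC(=O)CN(c1nc(Cl)nc2[nH]cnc12)C1CC1)C(=O)O` share one core and were both tested in a functional assay on the whole organism (Tail, strain ICR) with Mus musculus as the target, in the tail flick test, with a stated time of 120 min, at a dose of 25 umol/kg by the oral route; a lower number here means a weaker effect, a higher number a stronger effect of the compound at the dose given. In this assay compound 1 gives 21.7%, while compound 2 gives 17%, the lower of the two numbers, though the gap lies within the scatter. Compound 3 `O=C(O)CNC(=O)CN(c1nc(Cl)nc2[nH]cnc12)C1CC1` differs from compound 2 by hydrogen in place of carbamoylmethyl on a saturated chain carbon bound to an amide-type nitrogen and a carbonyl carbon. Among the measured compounds shown here, no measured pair isolates this change, so the step from compound 2 to compound 3 in this assay is expected to be small, a number 1 percentage points higher from compound 2 to compound 3 (within the scatter), with no direction beyond the scatter. Compound 3 is therefore estimated at 18%, between 5% and 32%.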

Compound 3, a percentage reported as activity, at one dose (the size of the read-out at that dose, not a potency): 19.8%
For compound 3 the middle estimate is 1.8 percentage points below the measured one, within the range that was stated.
By their numbers in this assay, from the lowest: compounds 2, 3 and 1 (each within the scatter of the next).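

In this assay hydrogen in place of carbamoylmethyl on a saturated chain carbon bound to an amide-type nitrogen and a carbonyl carbon gives a number 2.8 percentage points higher from compound 2 to compound 3 (within the scatter) and so stays inside the scatter. Hydrogen in place of benzyl on an oxygen next to a carbonyl group gives a number 1.9 percentage points lower from compound 1 to compound 3 (within the scatter) and stays inside it as well, so at this dose neither group is shown to matter. No measurement offered here bears on these results.

Going by these compounds, whether an amine or a longer chain on that saturated carbon would move the number beyond the scatter remains open. So does the effect of a methyl ester in place of the carboxylic acid of compound 3.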